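The source may report more compounds than this note shows. Statements on the series, on what has been measured and on what is new or still open speak of the compounds shown alone.

Measured compounds in an assay on isolated protein for inhibition of Apoptosis regulator Bcl-2 (Homo sapiens), read by fluorescence polarization; a higher number here means a weaker inhibitor, a lower number a stronger inhibitor:
- compound 1 `O=C(O)c1ccc(COc2ccc(/C=C3\SC(=S)N(c4ccc([N+](=O)[O-])cc4)C3=O)cc2)cc1`: a limit of the assay, > 10000 nM
- compound 2 `COc1ccc(N2C(=O)/C(=C/c3ccc(OCc4ccc(C(=O)O)cc4)cc3)SC2=S)cc1`: a limit of the assay, > 10000 nM
- compound 3 `O=C(O)c1ccc(COc2ccc(/C=C3\SC(=S)N(c4cccc(C(F)(F)F)c4)C3=O)cc2)cc1`: a limit of the assay, > 10000 nM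

Compound 3 thus stands only at a limit in this assay, and the two other values are limits as well (the limit of > 10000 nM in this assay, at which 3 of the 3 values shown sit). The steps from compound 1 to compound 2 a step that the two limits leave unreadable from compound 1 to compound 2, from compound 1 to compound 3 a step that the two limits leave unreadable from compound 1 to compound 3 and from compound 2 to compound 3 a step that the two limits leave unreadable from compound 2 to compound 3 are all unreadable in size.

Compound 4 `O=C(O)c1ccc(COc2ccc(/C=C3\SC(=S)N(Cc4ccc(F)cc4)C3=O)cc2)cc1` differs from compound 3 in one place (4-fluorobenzyl in place of 3-(trifluoromethyl)phenyl on an amide-type nitrogen in a ring). Among the compounds with values here, no measured step bears on a change of this kind, and none of the measured steps has a readable size, so no direction can be taken from them. Compound 4 is expected to remain at the limit, with the estimated step from compound 3 to compound 4 a step that the limit leaves unreadable from compound 3 to compound 4. The estimate for compound 4 in this assay is 20000 nM, range 5000 nM to 80000 nM.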

Compound 4, inhibition constant: > 10000 nM
Compound 4 gave a limit, no number; the forecaster's own chance of this, stated with the estimate: 80%; the middle value does not contradict the limit.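

Within the data shown here, compound 4 gives the limit > 10000 nM and no number, so no step to it from compound 1, compound 2 or compound 3 can be read.

In this assay the compounds shown leave open whether any group on the amide-type nitrogen changes the inhibition constant.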